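This account rests on a few compounds, and the source may have more. Where it says the series, first, only, none or still open, it means among the compounds named here.

Compound 1 `CCCCCN(Cc1ccc(C(=O)NO)cc1)c1ncc(-c2ccc(C)cc2)s1` is the reference point of this small set. Among the compounds with values here, in a functional assay on PC-3 cells (Homo sapiens) for antiproliferative activity, read by MTT assay, with a stated time of 48 h (a higher number here means a weaker inhibitor of growth, a lower number a stronger inhibitor of growth), compound 1 gives 5060 nM, the lowest of the three numbers measured so far. Compound 2 `Cc1ccc(-c2cnc(N(Cc3ccc(C(=O)NO)cc3)CC(C)C)s2)cc1` gives 9340 nM in this assay, and compound 3 `Cc1ccc(-c2cnc(N(CCCCOc3ccccc3)Cc3ccc(C(=O)NO)cc3)s2)cc1` gives 10300 nM. The step of a 1.8-fold higher number from compound 1 to compound 2 (0.27 log units; within the scatter) lies within the scatter, the step of a 2.0-fold higher number from compound 1 to compound 3 (0.31 log units; beyond the scatter) is a modest one beyond it, and the step of a 1.1-fold higher number from compound 2 to compound 3 (0.04 log units; within the scatter) is again within the scatter.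

Compound 4 `CCCCN(Cc1ccc(C(=O)NO)cc1)c1ncc(-c2ccc(C)cc2)s1` differs from compound 1 by hydrogen in place of methyl on a saturated chain carbon, four bonds along the chain from a nitrogen on an aromatic ring. Within the data shown here, the steps that bear on this change are those that alter the chain on the nitrogen of the shared core, a 1.8-fold higher number from compound 1 to compound 2 (0.27 log units; within the scatter) and a 2.0-fold higher number from compound 1 to compound 3 (0.31 log units; beyond the scatter). Both move the number only a little, and the second of them touches the same saturated chain carbon, four bonds along the chain from a nitrogen on an aromatic ring, that the new change does. Neither gives reason to expect much movement, so for compound 4 the estimated step is a 1.2-fold higher number from compound 1 to compound 4 (0.07 log units; within the scatter), nothing beyond the scatter. Compound 4 is therefore estimated at 6000 nM in this assay, with a range from 3000 nM to 12000 nM.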

Compound 4, concentration for 50% growth inhibition: 6410 nM
For compound 4 the middle estimate is 1.1-fold (0.03 log units) below the measured one; low and high end bracket the measured number.
By their numbers in this assay, from the lowest: compounds 1, 4, 2 and 3 (each within the scatter of the next, the first and the last beyond it).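

At this saturated chain carbon, four bonds along the chain from a nitrogen on an aromatic ring, hydrogen in place of methyl gives a step within the scatter in this assay (a 1.3-fold higher number from compound 1 to compound 4 (0.10 log units; within the scatter)), so removing that one methyl leaves no readable trace. Hydrogen in place of phenoxy at the same carbon also stays within the scatter (a 1.6-fold lower number from compound 3 to compound 4 (0.21 log units; within the scatter)), which means that compound 4 cannot be told apart from compound 3, even though the step from compound 1 to compound 3 lay just beyond it. Closer to the nitrogen, on a saturated chain carbon bound to a nitrogen on an aromatic ring, propyl in place of isopropyl likewise gives a step within the scatter (a 1.5-fold lower number from compound 2 to compound 4 (0.16 log units; within the scatter)), so the butyl chain of compound 4 and the branched chain of compound 2 read alike here.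

The compounds shown leave open whether a much shorter chain such as ethyl, or a chain ending in an amine or a carboxylic acid, would move the number beyond the scatter. Nothing shown explains why these chains read so much alike.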